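The source may hold more compounds than are shown below. What is called first, only, known or untested is meant among the compounds shown, and "the series" means these compounds.

In a functional assay on HepG2 cells (Homo sapiens) for inhibition, with a stated time of 72 h (on this read-out lower numbers stand for stronger inhibition and higher numbers for weaker inhibition), two compounds of this series have been measured. Compound 1 `Cc1cc(Cl)ccc1NC(=O)Nc1nc(NC2CC2)cc(Sc2c[nH]c3ccccc23)n1` gives 9740 nM in this assay. Compound 2 `COc1ccc(NC(=O)Nc2nc(Sc3c[nH]c4ccccc34)cc(N3CCCCC3)n2)cc1` gives 17100 nM in this assay and holds the highest of the two numbers, with compound 1 as its nearest neighbour, a gap that lies within the usual scatter of repeated measurements, so no order between the two can be read from it.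

Compound 3 `COc1ccc(NC(=O)Nc2nc(Nc3cc(OC)cc(OC)c3)cc(Sc3c[nH]c4ccccc34)n2)cc1` has not yet been measured. Compared with compound 2 it differs in one place ((3,5-dimethoxyphenyl)amino in place of piperidin-1-yl on an aromatic carbon), the group leaving and the group entering sitting on an aromatic carbon of a six-membered aromatic ring with 2 nitrogen, meta to a (1H-indol-3-yl)sulfanyl group.

Among the measured compounds shown here, the two values in this assay are close to each other, and no step between them is beyond the scatter, so the data offer no measured change to lean on. The step from compound 2 to compound 3 is expected to be a 1.9-fold lower number from compound 2 to compound 3 (0.28 log units; within the scatter), that is, not clearly beyond the scatter in either direction. Compound 3 is accordingly estimated to give about 9000 nM in this assay, within a range from 2500 nM to 30000 nM.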

Compound 3, half-maximal inhibitory concentration: 17400 nM
For compound 3 the middle estimate is 1.9-fold (0.29 log units) below the measured one; the range from low to high includes it.
By their numbers in this assay, from the lowest: compounds 1, 2 and 3 (each within the scatter of the next).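

In this assay the exchange of piperidin-1-yl for (3,5-dimethoxyphenyl)amino is a 1.0-fold higher number from compound 2 to compound 3 (0.01 log units; within the scatter) and gives the only reading of a single change among the compounds shown. It shows that this aromatic carbon, meta to a (1H-indol-3-yl)sulfanyl group, carries a saturated ring of 6 heavy atoms and an aryl amino group of 11 heavy atoms, with a hydrogen-bond donor that piperidin-1-yl lacks, at numbers that cannot be told apart. Nothing measured here bears on why these two groups cannot be told apart in this read-out.

Compound 1 differs from compound 2 and from compound 3 in more than one place, so those steps cannot be read. From the compounds shown here alone, it remains open whether any group at this carbon, such as morpholin-4-yl, a primary amine or a carboxylic acid on the aryl ring, would move the number beyond the scatter, or whether the read-out depends more on the aryl group on the urea of the shared core.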